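Working notes: lengthening the amide side chain

The compounds below may be only part of what the source reports. "The series", "measured", "known", "first", "only" and "open" are said of these compounds alone.

Measured so far in a functional assay on A 172 cells (Homo sapiens) for cytotoxicity, read by colorimetric assay and MTT assay; on this read-out lower numbers stand for stronger inhibition and higher numbers for weaker inhibition:
Compound 1 `COc1ccc2cc(-c3ccccc3)c(O)nc2c1` gives 10000 nM
Compound 2 `CCN(CC)C(=O)Cn1c(=O)c(-c2ccc(OC)cc2)cc2c(OC)cc(OC)cc21` gives 10000 nM

Compound 2 at 10000 nM stands level with compound 1, and the two values lie within the usual scatter of each other. Neither compound ranks ahead of the other on these numbers.

Compound 3 `CCN(CC)C(=O)CCn1c(=O)c(-c2ccc(OC)cc2)cc2c(OC)cc(OC)cc21` keeps the shared core of compound 2 and differs in one place, on a saturated chain carbon bound to an aromatic nitrogen. The change is (diethylcarbamoyl)methyl in place of diethylcarbamoyl on a saturated chain carbon bound to an aromatic nitrogen and, cut one bond further out, it reads (diethylcarbamoyl)methyl to 2-(diethylcarbamoyl)ethyl.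

Within the data shown here, no measured pair differs in a single place, so no step size can be read directly from the data. In this assay no step beyond the scatter is expected in either direction. This expectation rests on compound 2 at 10000 nM and on the small size of the structural change. An estimated no change at the digits printed from compound 2 to compound 3 (within the scatter) amounts to no shift beyond the scatter. Expected for compound 3 is 10000 nM within an estimated range from 4000 nM to 25000 nM in this assay for this series.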

Compound 3, half-maximal inhibitory concentration: 10000 nM
Compound 3: the middle estimate sits on the measured number at the digits printed; measured number inside the range.
By their numbers in this assay, from the lowest: compounds 1, 2 and 3 (each within the scatter of the next).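

In this assay the series now has its first comparison of two compounds differing in one place, and it reads no change at the digits printed from compound 2 to compound 3 (within the scatter) for the change from (diethylcarbamoyl)methyl to 2-(diethylcarbamoyl)ethyl. At this place, on a saturated chain carbon bound to an aromatic nitrogen, the extended chain with its diethylcarbamoyl end leaves the read-out level with the shorter one, which the level values of compound 1 and compound 2 alone could not show, as those two compounds differ in more than one place. No measurement given here accounts for this result, and the step is recorded as an observation only.

Open, going by these compounds, is whether a longer chain, or an amine or a carboxylic acid in place of the diethylcarbamoyl group at the chain end, would move the value at this place beyond the scatter in this assay and in which direction. Also open, on these data alone, is whether replacing the 4-methoxyphenyl or the methoxy groups on the shared core would give any step of that size, since this single step covers only the chain length.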